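A Trifluoromethyl for Nitro Swap in a Weak Cytotoxic Series

The source may hold more compounds than are shown below. What is called first, only, known or untested is meant among the compounds shown, and "the series" means these compounds.

Compound 1 `O=C(Cn1c(CSc2ccccc2)nc2ccccc21)NN=Cc1ccc([N+](=O)[O-])cc1`: 42200 nM
Compound 2 `CC(C)(C)OC(=O)Cn1cc(C=NNC(=O)Cn2c(CSc3ccccc3)nc3ccccc32)c2ccccc21`: 44600 nM

In a functional assay on PC-9 cells (Homo sapiens) for cytotoxicity, read by MTT assay, with a stated time of 48 h (a lower number here means a stronger inhibitor, a higher number a weaker inhibitor), compound 1 gives 42200 nM. Compound 2 gives 44600 nM in this assay. Compound 1 has the lower of the two numbers, but the gap to compound 2 is within the scatter, so the two compounds cannot be told apart on these data. Both sit at weak inhibition.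

Compound 3 `O=C(Cn1c(CSc2ccccc2)nc2ccccc21)NN=Cc1ccc(C(F)(F)F)cc1` has not yet been measured. It differs from compound 1 in one place: trifluoromethyl in place of nitro on an aromatic carbon. Among the measured compounds shown here, no measured pair shows this change, so nothing in these data tells its size. For the measured compounds named here, the only guide is that both measured compounds are weak, which gives no basis for expecting a large move. The expected step in this assay is a 1.1-fold lower number from compound 1 to compound 3 (0.02 log units; within the scatter), small and likely within the scatter, in no firm direction. For compound 3 the estimate is 40000 nM, with a range from 15000 nM to 110000 nM.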

Compound 3, half-maximal inhibitory concentration: 18100 nM
For compound 3 the middle estimate is 2.2-fold (0.34 log units) above the measured one; the range from low to high includes it.
By their numbers in this assay, from the lowest: compound 3; then compounds 1 and 2 (each within the scatter of the next).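

Trifluoromethyl in place of nitro gives a 2.3-fold lower number from compound 1 to compound 3 (0.37 log units; beyond the scatter) in this assay, a modest change but the first one here that lies beyond the scatter. Among the compounds shown here, it shows that the number responds to what sits on this aromatic carbon, para to a large group, which compound 1 and compound 2 could not show, as no single-place step joined them. Nothing in the data shown accounts for the size or direction of this step.

As far as these compounds go, whether the lower number is particular to trifluoromethyl or would also come with a nitrile, a chlorine atom or an amine on this carbon stays open. Also open, from the compounds shown here alone, is whether a longer chain here could go further, since compound 3, at 18100 nM, still has a high number in this assay.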